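The source may report more compounds than this note shows. Statements on the series, on what has been measured and on what is new or still open speak of the compounds shown alone.

Compound 1 `Cc1ccccc1N(C)C(=O)c1ccc(-c2cccc(O)c2)o1` gives 150 nM in an assay on cytosol from placenta for inhibition of 17-beta-hydroxysteroid dehydrogenase type 1 (Homo sapiens), read by HPLC, with a stated time of 10 min, in the presence of a further agent that is not named here; a lower number here means a stronger inhibitor, a higher number a weaker inhibitor.
Compound 2 `Cc1ccccc1N(C)C(=O)c1ccc(-c2ccc(O)c(F)c2)o1` gives 11 nM in this assay.
Compound 3 `Cc1ccc(F)cc1N(C)C(=O)c1ccc(-c2ccc(O)cc2)o1` gives 41 nM in this assay.

Among these three, compound 3 stands in the middle: its number is lower than that of compound 1 and higher than that of compound 2, and both of those gaps are beyond the scatter. Going by the values given here, the only step measured between compounds differing in a single place is a 14-fold lower number from compound 1 to compound 2 (1.13 log units; beyond the scatter), a large shift that comes from the hydroxyphenyl part of the core and not from the group on the amide nitrogen.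

Compound 4 `Cc1c(F)cccc1N(C)C(=O)c1ccc(-c2ccc(O)cc2)o1` has not yet been measured. It differs from compound 3 in 3-fluoro-2-methylphenyl in place of 5-fluoro-2-methylphenyl on an amide-type nitrogen. Among the compounds with values here, no measured pair in this set changes the group on the amide nitrogen, so there is no step that bears directly on this move; the change swaps the position of a fluorine on a ring that is already present in compound 3, and nothing in the data says which way, if any, the number should move. The expectation is therefore a step of a 1.0-fold lower number from compound 3 to compound 4 (0.01 log units; within the scatter), one that is not expected to go beyond the scatter in either direction. Compound 4 is estimated at 40 nM, with a range from 15 nM to 110 nM.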

Compound 4, half-maximal inhibitory concentration: 170 nM
Compound 4: middle estimate off by 4.3-fold (0.63 log units), on the low side; the whole stated range lies below it.
By their numbers in this assay, from the lowest: compound 2; then compound 3; then compounds 1 and 4 (each within the scatter of the next).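

Moving the fluorine on the ring carried by the amide nitrogen is not a silent change in this assay and 3-fluoro-2-methylphenyl in place of 5-fluoro-2-methylphenyl gives a 4.1-fold higher number from compound 3 to compound 4 (0.62 log units; beyond the scatter) as a modest step beyond the scatter. Going by these compounds alone, the earlier compounds held no step at this place, and this pair is the first to show that the group on the amide-type nitrogen matters for the number, even though the group that leaves and the group that enters have the same heavy atoms, the same aromatic ring and the same counts of hydrogen-bond donors and acceptors. Nothing available explains why the two arrangements differ.

The compounds shown leave open how a chlorine or a methoxy group in place of the fluorine on that ring would compare with compound 3 and compound 4. They also leave open whether the same move of the fluorine would give a step of similar size on a core carrying the 3-fluoro-4-hydroxyphenyl of compound 2, since the two changes have not been seen together.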